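A few compounds are considered here, and "the series" means these few. Any claim that something is new, unique, unknown or untested is made for them only; others in the source may bear on it.

Three close relatives have been tested in a functional assay on HT-29 cells (Homo sapiens) for cytotoxicity, read by MTT assay, with a stated time of 72 h (on this read-out higher numbers stand for weaker inhibition and lower numbers for stronger inhibition), all sharing one core and differing only in the aromatic group carried on the aromatic nitrogen. Compound 1 `Cc1c(C(=O)Nc2ccc(Oc3ccnc4[nH]ccc34)c(F)c2)nnn1-c1ccccc1F` gives 180 nM. Compound 2 `COc1ccc(-n2nnc(C(=O)Nc3ccc(Oc4ccnc5[nH]ccc45)c(F)c3)c2C)cc1` gives 590 nM. Compound 3 `Cc1c(C(=O)Nc2ccc(Oc3ccnc4[nH]ccc34)c(F)c2)nnn1-c1ccc(F)c(F)c1` gives 610 nM, the highest of the three numbers; its gap to compound 2 falls within the scatter, while a 3.4-fold higher number from compound 1 to compound 3 (0.53 log units; beyond the scatter) lies beyond it, as does a 3.3-fold higher number from compound 1 to compound 2 (0.52 log units; beyond the scatter). Compound 4 `Cc1c(C(=O)Nc2ccc(Oc3ccnc4[nH]ccc34)c(F)c2)nnn1-c1ccc(F)c(Cl)c1` is yet to be measured. It differs from compound 3 by chloro in place of fluoro on an aromatic carbon. For the measured compounds named here, no measured step swaps one halogen for another on this ring; the known steps all alter that ring more broadly, and even the largest of them was modest, with a 1.0-fold higher number from compound 2 to compound 3 (0.01 log units; within the scatter) being within the scatter. On that basis the change is expected to give a 1.0-fold lower number from compound 3 to compound 4 (0.01 log units; within the scatter), that is, nothing beyond the scatter in this assay. Compound 4 is therefore estimated at 600 nM, within a range from 250 nM to 1500 nM.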

Compound 4, half-maximal inhibitory concentration: 1060 nM
Estimate against measurement, compound 4: 1.8-fold (0.25 log units) below; the measured number falls inside the stated range.
By their numbers in this assay, from the lowest: compound 1; then compounds 2, 3 and 4 (each within the scatter of the next).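

In this assay, for the compounds shown here, this is the first direct swap of one halogen for another on this ring, and chloro in place of fluoro gives a 1.7-fold higher number from compound 3 to compound 4 (0.24 log units; within the scatter), so this change does not clearly separate the two compounds. The 3-chloro-4-fluorophenyl and 4-methoxyphenyl groups also remain close, with a 1.8-fold higher number from compound 2 to compound 4 (0.25 log units; within the scatter), while the 2-fluorophenyl group of compound 1 stays clearly apart from the new compound, with a 5.9-fold higher number from compound 1 to compound 4 (0.77 log units; beyond the scatter). No measurement shown here explains these differences.

Still open, as far as these compounds go, is whether bromo, methyl or an amine at this position would give a number close to those of the chloro and fluoro compounds. Also open, from the compounds shown here alone, is whether chloro in place of fluoro on the ring of compound 1 would give a step of similar size.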